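The source may report more compounds than this note shows. Statements on the series, on what has been measured and on what is new or still open speak of the compounds shown alone.

Three compounds have been taken through an ADME assay on CHO cells (Cricetulus griseus) for cytotoxicity, read by LDH release; a higher number here means a weaker inhibitor, a lower number a stronger inhibitor. For compound 1 `CC(C(=O)NCc1ccc(F)cc1)S(=O)(=O)c1ccc(Cl)cc1Cl` the entry reads "not determined" (no result reported). Compound 2 `COC(=O)C(NC(=O)C(C)Oc1ccc(Cl)cc1Cl)c1ccc(F)cc1` gives > 100000 nM, which is a limit of the assay and not a number. Within the data shown here, compound 3 `CC(Oc1ccc(Cl)cc1Cl)C(=O)NCc1ccc(Cl)cc1`, at 39000 nM, holds the only actual number in the set, so it has no measured neighbour to be ranked against.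

The next compound to be tested is compound 4 `Cc1ccccc1CNC(=O)C(C)Oc1ccc(Cl)cc1Cl`. It has 2-methylphenyl in place of 4-chlorophenyl on a saturated chain carbon bound to an amide-type nitrogen, and the counted difference is 2-methylphenyl in place of 4-chlorophenyl on a saturated chain carbon bound to an amide-type nitrogen. Among the measured compounds shown here, no measured pair differs in one place only, so this assay offers no precedent for this exchange. No change beyond the usual scatter is expected, and neither direction is favoured. The estimated step of a 1.0-fold higher number from compound 3 to compound 4 (0.01 log units; within the scatter) is accordingly small, though the uncertainty around it is wide. Compound 4 is expected to read about 40000 nM, with an estimated range from 15000 nM to 100000 nM.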

Compound 4, half-maximal inhibitory concentration: > 100000 nM
Compound 4 ended at the assay's limit; the forecaster's own chance of this, stated with the estimate: 20%; middle value at least 2.5-fold (0.39 log units) away from the limit.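

In this assay, among these compounds, the exchange of 4-chlorophenyl for 2-methylphenyl on a saturated chain carbon bound to an amide-type nitrogen gives the first readable step of the set: an at least 2.5-fold higher number from compound 3 to compound 4 (0.40 log units; beyond the scatter). The reading at this position is therefore sensitive to the group placed there, even though the two groups have the same number of heavy atoms and each is a six-membered aromatic ring of carbon only. The entry for compound 4 is a limit of the assay and not a number, so the true size of the step cannot be read because it is bounded on one side only: the limit of > 100000 nM in this assay, at which 2 of the 4 values shown sit.

The exchange changes both the substituent and its place on the ring, and the compounds shown do not separate the two. A 4-methylphenyl or 2-chlorophenyl group at this position would be needed to tell them apart.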